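Series notes: N-methyl to N-hydrogen step toward compound 3

This account rests on a few compounds, and the source may have more. Where it says the series, first, only, none or still open, it means among the compounds named here.

Of the compounds shown here, two have numbers so far. Compound 1 `O=C(Nc1ccc(Oc2ccnc3[nH]ccc23)cc1)c1cn(-c2ccccc2)c2ccccc2c1=O` in a functional assay on A549 cells (Homo sapiens) for inhibition, read by MTT assay, with a stated time of 72 h (on this read-out higher numbers stand for weaker inhibition and lower numbers for stronger inhibition), gives 1030 nM. Compound 2 `Cn1ccc2c(Oc3ccc(NC(=O)c4cn(-c5ccccc5)c5ccccc5c4=O)cc3F)ccnc21` in this assay gives 1720 nM, the highest of the two numbers; its gap to compound 1 lies within the scatter, so the two show no difference that can be read as one.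

Compound 3 `O=C(Nc1ccc(Oc2ccnc3[nH]ccc23)c(F)c1)c1cn(-c2ccccc2)c2ccccc2c1=O` has not yet been measured in this assay. It differs from compound 2 by hydrogen in place of methyl on an aromatic nitrogen, which is hydrogen in place of methyl on an aromatic nitrogen. Within the data shown here, no measured pair isolates this change, and compound 1 already carries the same hydrogen on that nitrogen with a number close to compound 2.

From compound 2 to compound 3 the expected step is a 1.3-fold lower number from compound 2 to compound 3 (0.12 log units; within the scatter), that is, none beyond the scatter. For compound 3 the estimate in this assay is 1300 nM, with a range from 500 nM to 3500 nM.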

Compound 3, half-maximal inhibitory concentration: 420 nM
Compound 3: middle estimate off by 3.1-fold (0.49 log units), on the high side; the measured number lies below the stated range.
By their numbers in this assay, from the lowest: compound 3; then compounds 1 and 2 (each within the scatter of the next).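

In this assay hydrogen in place of methyl on the aromatic nitrogen gives a 4.1-fold lower number from compound 2 to compound 3 (0.61 log units; beyond the scatter) and so shows that this position can move the number beyond the scatter, which the earlier pair, differing in two places, could not show. With hydrogen on that nitrogen in both compounds, fluoro in place of hydrogen on an aromatic carbon gives a 2.5-fold lower number from compound 1 to compound 3 (0.39 log units; beyond the scatter) as a second single change beyond the scatter, one that the printed values of compound 1 and compound 2 gave no sign of. No measurement shown here accounts for either step.

From the compounds shown here alone, each step rests on one pair, and whether the nitrogen step holds without the fluoro remains open. Also open, going by these compounds, is how an ethyl group or a longer chain on that nitrogen, or chloro or methoxy on that carbon, would read.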